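The source may hold more compounds than are shown below. What is called first, only, known or untested is meant among the compounds shown, and "the series" means these compounds.

Compound 1 `COc1ccc(COc2cc(-c3ccco3)nc(Cl)n2)cc1` and compound 2 `COc1ccc(COc2ncnc(-c3ccco3)c2[N+](=O)[O-])cc1` share a core with the pair that this account follows. In an ADME assay on Vero cells (Chlorocebus sabaeus) for cytotoxicity, read by MTT assay, with a stated time of 72 h (on this read-out lower numbers stand for stronger inhibition and higher numbers for weaker inhibition), compound 1 gives "not determined" (no result reported). In this assay compound 2 gives "not determined" (no result reported). Compound 3 `COc1ccc(CNc2nc(F)nc(-c3ccco3)c2NC=O)cc1` is the only one of the three with a reported result, and that result is a limit of the assay: in this assay compound 3 gives > 40 ug/mL. This is the limit of > 40 ug/mL in this assay, at which 1 of the 3 values shown sits. Within the data shown here, compound 3 thus stands at the edge of what the assay reports, with no single number and with no step between measured compounds to set it against. Compound 4 `CCc1nc(NCc2ccc(OC)cc2)c(NC=O)c(-c2ccco2)n1` differs from compound 3 by ethyl in place of fluoro on an aromatic carbon. Among the measured compounds shown here, no measured step covers such a change, and the step from compound 3 to compound 4 in this assay is expected to be none beyond the scatter. The estimate for compound 4 in this assay is 40 ug/mL, with an expected range from 20 ug/mL to 80 ug/mL, which means an expected step of a number no higher from compound 3 to compound 4 (the limit leaves the size open).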

Compound 4, half-maximal inhibitory concentration: > 40 ug/mL
Compound 4 gave a limit, no number; the forecaster's own chance of this, stated with the estimate: 70%; the middle value lies on the limit itself.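

Compound 3 and compound 4 both stop at a limit of this assay and give no number, so no new step can be read between them: the limit of > 40 ug/mL in this assay, at which 2 of the 4 values shown sit.

The compounds shown leave open how far compound 3 and compound 4 lie from that limit, and whether ethyl in place of fluoro alters the result in this assay.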